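Notes on compound 4: amino in place of methoxy

The source may hold more compounds than are shown below. What is called first, only, known or untested is meant among the compounds shown, and "the series" means these compounds.

Measured compounds:
- Compound 1 `CN1CCN(CCNCc2cn(-c3ccc(F)cc3F)nc2-c2ccc(OC(F)(F)F)cc2)CC1`: in an ADME assay on Huh-7 cells (Homo sapiens) for cytotoxicity (a lower number here means that less compound is tolerated, a higher number that more compound is tolerated), compound 1 gives 18000 nM.
- Compound 2 `COc1ccc(-n2cc(CNCCN3CCN(C)CC3)c(-c3ccccc3C)n2)cc1`: in this assay compound 2 gives > 20000 nM, which is a limit of the assay and not a number.
- Compound 3 `CN1CCN(CCNCc2cn(-c3ccc(F)cc3F)nc2-c2cccc(Cl)c2)CC1`: in this assay compound 3 gives 15000 nM.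

Where compound 2 stands: in this assay compound 2 is known only as the limit of > 20000 nM in this assay, at which 1 of the 3 values shown sits, so no number places it against compound 1 or compound 3. Going by the values given here, the single step between measured compounds, a 1.2-fold lower number from compound 1 to compound 3 (0.08 log units; within the scatter), concerns a different part of the shared core and leaves the methoxy untouched, so it does not bear on the change in hand.

Compound 4 `Cc1ccccc1-c1nn(-c2ccc(N)cc2)cc1CNCCN1CCN(C)CC1` differs from compound 2 by amino in place of methoxy on an aromatic carbon. Among the compounds with values here, no measured step covers this exchange, and the starting point is itself only a limit; the expectation is therefore no step beyond the scatter, with the estimate a number no higher from compound 2 to compound 4 (the limit leaves the size open). For compound 4 the value in this assay is expected to be 20000 nM, with a range from 9000 nM to 40000 nM, and a fair chance that only a limit is reported again.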

Compound 4, half-maximal cytotoxic concentration: > 20000 nM
Compound 4: only a limit was reported; the forecaster's own chance of this, stated with the estimate: 55%; the middle value sits exactly at the limit.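

In this assay compound 4 gives > 20000 nM, a limit of the assay and not a number. Compound 2 is likewise known only as a limit, so no step between compound 2 and compound 4 can be read: the limit of > 20000 nM in this assay, at which 2 of the 4 values shown sit.

The compounds shown leave open how amino and methoxy on this aromatic carbon compare in this assay.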